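Half-life notes on the shared core series

The source may hold more compounds than are shown below. What is called first, only, known or untested is meant among the compounds shown, and "the series" means these compounds.

Compound 1 `CCCCC(=O)O[C@@H]1CO[C@H]2[C@@H]1OC[C@@H]2OC(=O)c1ccccc1OC(C)=O` has the lowest number of the three measured compounds in an ADME assay on a cell-free system (plasma, Homo sapiens) for metabolic stability, with Plasma (Rattus norvegicus) as the target, read by HPLC, at pH 7.4 (on this read-out lower numbers stand for a shorter-lived compound and higher numbers for a longer-lived compound), giving 0.0117 h. Compound 2 `COc1ccc(C(=O)O[C@@H]2CO[C@H]3[C@@H]2OC[C@@H]3OC(=O)c2ccccc2OC(C)=O)cc1` gives 0.0183 h and compound 3 `CC(=O)Oc1ccccc1C(=O)O[C@H]1CO[C@H]2[C@@H]1OC[C@H]2OC(=O)c1ccc([N+](=O)[O-])cc1` gives 0.0227 h. The step of a 1.6-fold higher number from compound 1 to compound 2 (0.19 log units; within the scatter) and the step of a 1.9-fold higher number from compound 1 to compound 3 (0.29 log units; within the scatter) both stay within the scatter, as does a 1.2-fold higher number from compound 2 to compound 3 (0.09 log units; within the scatter).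

Compound 4 `CC(=O)Oc1ccccc1C(=O)O[C@H]1CO[C@H]2[C@@H]1OC[C@H]2OC(=O)c1ccc(CO[N+](=O)[O-])cc1` differs from compound 1 by 4-((nitrooxy)methyl)phenyl in place of butyl on a carbonyl carbon. The two measured steps out of compound 1 bear directly on this change, since each replaces butyl on a carbonyl carbon, and neither moved beyond the scatter. For compound 4 the expected step is therefore a 1.7-fold higher number from compound 1 to compound 4 (0.23 log units; within the scatter), a number not beyond the scatter. The estimate for compound 4 is 0.02 h, with a range from 0.008 h to 0.05 h.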

Compound 4, half-life: 0.04 h
Beside the measured number, compound 4's estimate is 2.0-fold (0.30 log units) below it, and the stated range covers the measured number.
By their numbers in this assay, from the lowest: compounds 1, 2, 3 and 4 (each within the scatter of the next, the first and the last beyond it).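

In this assay the series gets its first steps beyond the scatter: a 3.4-fold higher number from compound 1 to compound 4 (0.53 log units; beyond the scatter) on the carbonyl carbon, with 4-((nitrooxy)methyl)phenyl in place of butyl, and a 2.2-fold higher number from compound 2 to compound 4 (0.34 log units; beyond the scatter) on the aromatic carbon, with (nitrooxy)methyl in place of methoxy. Against nitro on that aromatic carbon, the same group does not separate, as a 1.8-fold higher number from compound 3 to compound 4 (0.25 log units; within the scatter) stays within the scatter. Nothing measured here bears on what lies behind these steps. Open, from the compounds shown here alone, is whether an amine or a carboxylic acid on that aromatic carbon, or a longer chain in place of butyl, would shift the half-life further.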